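Fluorine on the Phenoxy Ring: What Compound 4 May Show

This account rests on a few compounds, and the source may have more. Where it says the series, first, only, none or still open, it means among the compounds named here.

Measured compounds:
compound 1 `O=C1c2cc(COc3ccccc3)nn2CCN1c1ccc(F)cc1F`: 101%
compound 2 `O=C1c2cc(COc3ccccc3)nn2CCN1c1cccnc1`: 64%
compound 3 `O=C1c2cc(COc3ccccc3)nn2CCN1c1ccc(F)cn1`: 72%

In a functional assay on HEK293 cells for positive allosteric modulation of metabotropic glutamate receptor 5 (Homo sapiens), read by calcium flux (on this read-out higher numbers stand for larger maximal responses and lower numbers for smaller maximal responses), compound 3 gives 72%, the second highest of the three numbers. Its nearest companion is compound 2, and that gap, a number 8 percentage points higher from compound 2 to compound 3 (within the scatter), lies within the scatter, whereas a number 29 percentage points lower from compound 1 to compound 3 (beyond the scatter) lies beyond it. Compound 4 `O=C1c2cc(COc3cccc(F)c3)nn2CCN1c1ccc(F)cn1` differs from compound 3 in one place: fluoro in place of hydrogen on an aromatic carbon, read one bond further out as phenoxy to 3-fluorophenoxy. Among the measured compounds shown here, none of the measured steps touches this ring: a number 37 percentage points lower from compound 1 to compound 2 (beyond the scatter) and a number 29 percentage points lower from compound 1 to compound 3 (beyond the scatter) both concern the group on the amide-type nitrogen in a ring. For the measured compounds named here, with no bearing step, compound 4 is expected to show no change at the digits printed from compound 3 to compound 4 (within the scatter), nothing beyond the scatter. The estimate for compound 4 is 72%, between 55% and 90%.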

Compound 4, largest response reached (Emax), in percent of the reference or control that the assay uses: 62%
For compound 4 the middle estimate is 10 percentage points above the measured one; the measured number falls inside the stated range.
By their numbers in this assay, from the lowest: compounds 4, 2 and 3 (each within the scatter of the next); then compound 1.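

In this assay, the first change shown on the phenoxy ring, fluoro in place of hydrogen on an aromatic carbon, gives a number 10 percentage points lower from compound 3 to compound 4 (within the scatter). This position therefore takes 3-fluorophenoxy without a step beyond the scatter, unlike the changes on the amide-type nitrogen that lead from compound 1 to compound 2 and to compound 3. Nothing available bears on the reason for this reading. Still open, as far as these compounds go, is how a larger group at this place, such as methoxy or trifluoromethyl, would read, and whether 3-fluorophenoxy would read the same alongside the 2,4-difluorophenyl group of compound 1.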